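From a 4-Hydroxyphenyl Group to Iodine on the Core

This account rests on a few compounds, and the source may have more. Where it says the series, first, only, none or still open, it means among the compounds named here.

Compound 1 `Cc1cc(-c2ccc(O)cc2)c2ncc(CSCCc3ccccc3)n2c1` carries a 4-hydroxyphenyl group on the shared core. In an ADME assay on HEL cells (Homo sapiens) for cytotoxicity, with a stated time of 3 days (a higher number here means that more compound is tolerated, a lower number that less compound is tolerated), compound 1 gives 13.7 ug/mL, the lowest of the three numbers measured. Compound 2 `COc1cccc(-c2cc(C)c3ncc(CSCCc4ccccc4)n3c2)c1` gives 36 ug/mL and compound 3 `Cc1cc(-c2ccccc2)cn2c(CSCCc3ccccc3)cnc12` gives 31 ug/mL; both stand beyond the scatter above compound 1. Within the data shown here, the only step between measured compounds, a 1.2-fold lower number from compound 2 to compound 3 (0.06 log units; within the scatter), concerns the methoxy group alone and stays within the scatter.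

Compound 4 `Cc1cc(I)c2ncc(CSCCc3ccccc3)n2c1` has not been measured. It differs from compound 1 in one place: iodo in place of 4-hydroxyphenyl on an aromatic carbon. Among the measured compounds shown here, no measured step removes the whole 4-hydroxyphenyl group, so nothing in the data speaks directly to this change, and the step from compound 2 to compound 3 shows only that a change of one group on that ring moved the number little. Compound 2 with 36 ug/mL and compound 3 with 31 ug/mL both lack the hydroxy group and stand higher than compound 1, which gives a weak lean upward for a compound that also lacks it. Compound 4 is therefore expected to land near compound 1, at 20 ug/mL, between 7 ug/mL and 60 ug/mL. The expected step in this assay is a 1.5-fold higher number from compound 1 to compound 4 (0.16 log units; within the scatter).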

Compound 4, half-maximal cytotoxic concentration: > 50 ug/mL
Compound 4 was reported as a limit; the forecaster's own chance of this, stated with the estimate: 10%; at least 2.5-fold (0.39 log units) between middle value and limit.
By their numbers in this assay, from the lowest: compound 1; then compounds 3 and 2 (each within the scatter of the next). At a limit, above all of these: compound 4.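

Among these compounds, the step to iodo, an at least 3.6-fold higher number from compound 1 to compound 4 (0.56 log units; beyond the scatter), is the first here that lies beyond the scatter in this assay; the only earlier step, which concerned a methoxy group, stayed within it. Compound 4 gives > 50 ug/mL, which is a limit of the assay and not a number, and the reading of this step rests on it: the limit of > 50 ug/mL in this assay, at which 1 of the 4 values shown sits. The step shows that what sits on this aromatic carbon, two atoms from the ring nitrogen and meta to a methyl group, can shift the number in this assay, and that a 4-hydroxyphenyl group there is not needed for a compound to reach the limit.

Among the compounds shown here, the single pair leaves open whether the loss of the hydroxy group, the loss of the whole aromatic ring or the arrival of iodine carries the step, and a plain phenyl, a 4-methoxyphenyl group or a chlorine at this place would be needed to tell these apart. As far as these compounds go, how an amine or a carboxylic acid at the same carbon would read in this assay also remains open.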